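Swapping the aniline ring on a shared quinazoline-thioether core

The source may hold more compounds than are shown below. What is called first, only, known or untested is meant among the compounds shown, and "the series" means these compounds.

Measured so far:
- compound 1, `O=C(CSc1nc(Nc2ccccc2)c2ccccc2n1)Nc1ccc(Cl)c(Cl)c1`, gives 14500 nM in a functional assay on MDA-MB-231 cells (Homo sapiens) for inhibition, read by MTT assay, with a stated time of 72 h; a lower number here means a stronger inhibitor, a higher number a weaker inhibitor
- compound 2, `C=CC(=O)Nc1cccc(NC(=O)CSc2nc(Nc3cccc(OC)c3)c3ccccc3n2)c1`, gives 12900 nM in this assay

Compound 2 has the lowest of the two numbers, yet its gap to compound 1 falls within the usual scatter, so the two cannot be ordered. Compound 3, `C=CC(=O)Nc1cccc(NC(=O)CSc2nc(Nc3ccc(Cl)cc3Cl)c3ccccc3n2)c1`, differs from compound 2 by 2,4-dichlorophenyl in place of 3-methoxyphenyl on a nitrogen on an aromatic ring. Among the measured compounds shown here, no measured pair isolates this change, so the step is expected to stay within the scatter, roughly a 1.1-fold lower number from compound 2 to compound 3 (0.03 log units; within the scatter). Compound 3 is therefore estimated at 12000 nM, with a range from 4500 nM to 32000 nM.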

Compound 3, half-maximal inhibitory concentration: 23100 nM
Estimate against measurement, compound 3: 1.9-fold (0.28 log units) below; low and high end bracket the measured number.
By their numbers in this assay, from the lowest: compounds 2, 1 and 3 (each within the scatter of the next).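

Among the compounds shown here, this pair is the first to isolate a change at this position: in this assay, the step is a 1.8-fold higher number from compound 2 to compound 3 (0.25 log units; within the scatter). Exchanging 3-methoxyphenyl for 2,4-dichlorophenyl on a nitrogen on an aromatic ring therefore gives two values that cannot be told apart, even though one ring carries a methoxy group and the other two chlorines. No measurement here offers an explanation for this result.

Going by these compounds, it remains open whether a different group here, such as a pyridine ring or a short alkyl chain, would move the number beyond the scatter. The same question applies to a phenyl ring carrying an amine or a carboxylic acid.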